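A Bromo Step From Compound 1

The source may report more compounds than this note shows. Statements on the series, on what has been measured and on what is new or still open speak of the compounds shown alone.

Compounds in a functional assay on WM-115 cells (Homo sapiens) for cytotoxicity, read by MTT assay, with a stated time of 46 h (on this read-out lower numbers stand for stronger inhibition and higher numbers for weaker inhibition), so far:
compound 1 `O=C1/C(=C\c2ccccc2)C(c2ccccc2)Oc2ccccc21` gives 52600 nM
compound 2 `O=C1/C(=C\c2ccccc2)C(c2ccccc2)Oc2ccc(O)cc21` gives 9100 nM
compound 3 `O=C1/C(=C\c2ccc(Br)cc2)C(c2ccccc2)Oc2ccccc21` is not yet measured

Compound 1 holds the higher of the two numbers in this assay and so stands as the weaker inhibitor. Compound 3 has bromo in place of hydrogen on an aromatic carbon, changing phenyl to 4-bromophenyl. For the measured compounds named here, the only measured step is a hydroxy change, a 5.8-fold lower number from compound 1 to compound 2 (0.76 log units; beyond the scatter), so it bears on this change only loosely. On that basis, a modest move towards a lower number is expected, and a 2.1-fold lower number from compound 1 to compound 3 (0.32 log units; beyond the scatter) is the estimated step. The estimated value for compound 3 is 25000 nM, with an expected range of 8000 nM to 70000 nM.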

Compound 3, half-maximal inhibitory concentration in the WM-115 assay: 32600 nM
Estimate against measurement, compound 3: 1.3-fold (0.12 log units) below; the range from low to high includes it.
By their numbers in the WM-115 assay, from the lowest: compound 2; then compounds 3 and 1 (each within the scatter of the next).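

In the WM-115 assay, bromo in place of hydrogen on an aromatic carbon, para to a large group, gives a 1.6-fold lower number from compound 1 to compound 3 (0.21 log units; within the scatter), so this change at this position does not separate the two compounds on that read-out. The earlier hydroxy step, a 5.8-fold lower number from compound 1 to compound 2 (0.76 log units; beyond the scatter), was made in another place and lay beyond the scatter. In a physicochemical assay for lipophilicity, read by HPLC (a higher number here means a more lipophilic compound, a lower number a more polar compound), compound 1 gives 3.9 and compound 3 gives 4.71. The bromo change does make the compound more lipophilic, as the physicochemical assay shows: the measured partition coefficient of compound 1, 3.9, and of compound 3, 4.71, a number 0.81 log units higher (beyond the scatter)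

The compounds shown leave open whether an amine or a carboxylic acid at this same position would move the number in the WM-115 assay beyond the scatter.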